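The source may hold more compounds than are shown below. What is called first, only, known or untested is meant among the compounds shown, and "the series" means these compounds.

Of the compounds shown here, three sharing one core have been measured in an ADME assay on microsomes from liver (Homo sapiens) for metabolic stability, read by LC-MS, using NADPH, with stated times of 5 min and 30 min, tested at 1 uM; on this read-out lower numbers stand for slow clearance and higher numbers for fast clearance. Compound 1 `Cc1cc(-c2cnc(NCc3c(F)ccc4c3CCO4)c3cn[nH]c(=O)c23)n(C)n1` gives 24 mL.min-1.g-1. Compound 2 `O=C(Nc1ccccc1)c1cnc(NCc2c(F)ccc3c2CCO3)n2cnnc12` gives 14 mL.min-1.g-1, and compound 3 `Cc1ncccc1-c1cnc(NCc2c(F)ccc3c2CCO3)n2c(=O)[nH]nc12` gives 36 mL.min-1.g-1. The gaps among these three values all fall within the usual scatter of this measurement, so none of the three can be set apart from the others on this read-out. Compound 4 `Cc1nn(C)cc1-c1cnc(NCc2c(F)ccc3c2CCO3)c2cn[nH]c(=O)c12` has not yet been measured. Its structure differs from compound 1 in one place: 1,3-dimethyl-1H-pyrazol-4-yl in place of 1,3-dimethyl-1H-pyrazol-5-yl on an aromatic carbon. Among the compounds with values here, no measured pair of this kind exists to lean on, so the expectation is for a step of no change at the digits printed from compound 1 to compound 4 (within the scatter), that is, none beyond the scatter. Compound 4 is therefore estimated at 24 mL.min-1.g-1, in a range from 12 mL.min-1.g-1 to 48 mL.min-1.g-1.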

Compound 4, intrinsic clearance in microsomes: 27 mL.min-1.g-1
Beside the measured number, compound 4's estimate is 1.1-fold (0.05 log units) below it; measured number inside the range.
By their numbers in this assay, from the lowest: compounds 2, 1, 4 and 3 (each within the scatter of the next, the first and the last beyond it).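

In this assay, putting 1,3-dimethyl-1H-pyrazol-4-yl in place of 1,3-dimethyl-1H-pyrazol-5-yl on this aromatic carbon gives a 1.1-fold higher number from compound 1 to compound 4 (0.05 log units; within the scatter) and so stays within the scatter. Within the data shown here, this is the first comparison here of compounds differing in only one place, and it shows that these two ways of attaching the same atoms cannot be told apart on this read-out. No supporting measurement here accounts for this result.

Going by these compounds, whether a different group on this carbon, such as an amine or a carboxylic acid, would shift clearance beyond the scatter remains open. So does whether this same exchange would give a similar result on a different core.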